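Chromanyl side-chain series: cytotoxicity notes on compound 3

This account rests on a few compounds, and the source may have more. Where it says the series, first, only, none or still open, it means among the compounds named here.

Measured so far:
compound 1 `COc1cc2c(cc1O)CCC(C)(CC(=O)O)O2` gives 92%
compound 2 `COc1cc2c(cc1O)CCC(C)(CCNC(C)=O)O2` gives 83.5%

In an ADME assay on SH-SY5Y cells (Homo sapiens) for cytotoxicity, read by MTT assay, with a stated time of 24 h, tested at 12.5 uM (on this read-out higher numbers stand for a weaker effect at the one concentration tested and lower numbers for a stronger effect), compound 2 stands as the lowest of the two numbers recorded, with compound 1 nearest, a gap that lies within the scatter. Among the measured compounds shown here, the one step available, a number 8.5 percentage points lower from compound 1 to compound 2 (within the scatter), therefore shows no effect beyond the scatter for the exchange of carboxy against acetamidomethyl on a saturated chain carbon bound to a saturated ring carbon.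

Compound 3 `COc1cc2c(cc1O)CCC(C)(CC(N)C(=O)O)O2` is not yet measured. It differs from compound 2 by amino(carboxy)methyl in place of acetamidomethyl on a saturated chain carbon bound to a saturated ring carbon. The incoming group carries the carboxy again, which compound 1 already holds, and that earlier exchange moved the number only within the scatter. For the measured compounds named here, no measured step covers the added amino, so nothing beyond that single comparison bears on it. On this basis the expected step from compound 2 to compound 3 in this assay is none beyond the scatter, estimated as a number 4.5 percentage points higher from compound 2 to compound 3 (within the scatter). For compound 3 the number expected in this assay is 88%, within a range from 72% to 100%.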

Compound 3, a percentage reported as activity, at one concentration (the size of the read-out at that concentration, not a potency): 100%
For compound 3 the middle estimate is 12 percentage points below the measured one; low and high end bracket the measured number.
By their numbers in this assay, from the lowest: compounds 2, 1 and 3 (each within the scatter of the next, the first and the last beyond it).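

In this assay, among the compounds shown here, the exchange on a saturated chain carbon bound to a saturated ring carbon now gives a step beyond the scatter for the first time: amino(carboxy)methyl in place of acetamidomethyl gives a number 16.5 percentage points higher from compound 2 to compound 3 (beyond the scatter) and so a modestly weaker effect at the one concentration tested. Against the carboxy of compound 1, the same incoming group gives a number 8 percentage points higher from compound 1 to compound 3 (within the scatter) and so cannot be told apart, which means that only compound 2 and compound 3 are separated at this position, while compound 1 lies within the scatter of both. No measured information here accounts for the step from compound 2 to compound 3.

Going by these compounds, the exchange from 2-acetamidoethyl to 2-amino-2-carboxyethyl alters the amide and the acid together, so the contribution of each remains open. A 2-aminoethyl chain with a free primary amine and no carboxylic acid, or a carboxylic acid on a longer chain, would help to separate these contributions, and the compounds shown say nothing about how either would read in this assay at this position.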